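Phenyl for nitro on the para-substituted aryl of compound 2

This account rests on a few compounds, and the source may have more. Where it says the series, first, only, none or still open, it means among the compounds named here.

Two amides sharing one core have been measured in a functional assay on the whole organism (integument) for inhibition, with Chilo suppressalis as the target, read by scintillation counting, with a stated time of 72 h; a higher number here means a weaker inhibitor, a lower number a stronger inhibitor. Compound 1 `COc1cccc(OC)c1C(=O)Nc1nnc(-c2ccc(C(C)(C)C)cc2)s1` gives 912 nM. Compound 2 `COc1cccc(OC)c1C(=O)Nc1nnc(-c2ccc([N+](=O)[O-])cc2)s1` gives 355 nM, the lowest of the two numbers, the nearest being compound 1 at a higher number; the step of a 2.6-fold lower number from compound 1 to compound 2 (0.41 log units; beyond the scatter) is described as modest. The unmeasured compound 3 `COc1cccc(OC)c1C(=O)Nc1nnc(-c2ccc(-c3ccccc3)cc2)s1` differs from compound 2 in one place: phenyl in place of nitro on an aromatic carbon. Going by the values given here, no measured step swaps nitro for phenyl, so the only guidance is indirect. Among the compounds with values here, the one step available, a 2.6-fold lower number from compound 1 to compound 2 (0.41 log units; beyond the scatter), shows that replacing tert-butyl at this position with nitro lowered the number beyond the scatter, and the change to compound 3 removes that nitro again in favour of another group without hydrogen-bond acceptors. Compound 3 is therefore expected to move back toward the number of compound 1, a step of a 2.0-fold higher number from compound 2 to compound 3 (0.29 log units; within the scatter) upward in this assay. Within the data shown here, the estimate for compound 3 is 700 nM, with a range from 250 nM to 2000 nM, and the uncertainty is wide given the single bearing step.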

Compound 3, half-maximal inhibitory concentration: 195 nM
Estimate against measurement, compound 3: 3.6-fold (0.56 log units) above; measured number outside the range, below it.
By their numbers in this assay, from the lowest: compounds 3 and 2 (each within the scatter of the next); then compound 1.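

In this assay, the swap of nitro for phenyl gives a 1.8-fold lower number from compound 2 to compound 3 (0.26 log units; within the scatter), so these two compounds cannot be told apart, even though the entering phenyl has 6 heavy atoms, one six-membered aromatic ring and 0 hydrogen-bond acceptors, against 3 heavy atoms, no ring and 2 hydrogen-bond acceptors in the leaving nitro. The hydrogen-bond acceptors of nitro are thus not required for a number at this level in these compounds, and with a 4.7-fold lower number from compound 1 to compound 3 (0.67 log units; beyond the scatter), tert-butyl is the group that stands apart from both nitro and phenyl at this position. No measurement offered here accounts for these differences.

On these data alone, whether an amine, a carboxylic acid or a longer chain such as n-hexyl at this aromatic carbon would group with compound 2 and compound 3 or with compound 1 remains open. Also open, as far as these compounds go, is whether the same ordering would hold if the two methoxy groups on the shared core were replaced, for example by fluorine atoms.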